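Lengthening the chain of compound 3

The compounds below may be only part of what the source reports. "The series", "measured", "known", "first", "only" and "open" are said of these compounds alone.

In a functional assay on PA-1 cells (Homo sapiens) for cytotoxicity, read by MTT assay, with a stated time of 4 h (on this read-out higher numbers stand for weaker inhibition and lower numbers for stronger inhibition), compound 1 `COC(=O)C1=CO[C@@H](O[C@@H]2O[C@H](COC(c3ccccc3)(c3ccccc3)c3ccccc3)[C@@H](OC(=O)O)[C@H](OC(C)=O)[C@H]2OC(C)=O)[C@@H]2[C@@H](C)[C@@H](OC(C)=O)C[C@H]12` gives 1.2 ug/mL and compound 3 `CCC(=O)OC[C@H]1O[C@@H](O[C@@H]2OC=C(C(=O)OC)[C@H]3C[C@H](OC(C)=O)[C@H](C)[C@@H]23)[C@H](OC(C)=O)[C@@H](OC(C)=O)[C@@H]1OC(C)=O` gives 1.24 ug/mL. These two numbers lie within the scatter of each other, so compound 3 stands level with the only other numeric entry. Compound 2 `COC(=O)C1=CO[C@@H](O[C@@H]2O[C@H](CO)[C@@H](OC(C)=O)[C@H](OC(C)=O)[C@H]2OC(C)=O)[C@@H]2[C@@H](C)[C@@H](OC(C)=O)C[C@H]12` is reported as "not active" (no number reported), with no number. Compound 4 `CCCCCCCCCCCC(=O)OC[C@H]1O[C@@H](O[C@@H]2OC=C(C(=O)OC)[C@H]3C[C@H](OC(C)=O)[C@H](C)[C@@H]23)[C@H](OC(C)=O)[C@@H](OC(C)=O)[C@@H]1OC(C)=O` differs from compound 3 by nonyl in place of hydrogen on a saturated chain carbon, two bonds along the chain from a carbonyl carbon, on a saturated chain carbon, two bonds along the chain from a carbonyl carbon. Going by the values given here, no measured pair isolates such a change, so no step beyond the scatter is expected in this assay, and no direction is favoured. The estimated change is a 1.0-fold higher number from compound 3 to compound 4 (0.02 log units; within the scatter). The anchor is compound 3 at 1.24 ug/mL. Compound 4 is estimated at 1.3 ug/mL, within an expected range of 0.4 ug/mL to 4 ug/mL.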

Compound 4, half-maximal inhibitory concentration: 0.15 ug/mL
Compound 4: middle estimate off by 8.7-fold (0.94 log units), on the high side; measured number outside the range, below it.
By their numbers in this assay, from the lowest: compound 4; then compounds 1 and 3 (each within the scatter of the next).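

Going by these compounds alone, with an 8.3-fold lower number from compound 3 to compound 4 (0.92 log units; beyond the scatter) in this assay as the only step read, the saturated chain carbon two bonds along the chain from a carbonyl carbon proves responsive to substitution. Nonyl in place of hydrogen there moves the number down, a change no earlier pair could isolate. Nothing available accounts for this step.

A single chain length leaves the shape of the trend open: a shorter chain such as butyl or a longer chain such as tetradecyl could show whether the number keeps falling with length. An amine or a carboxylic acid at this place would show whether the step needs an all-carbon chain.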